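Amide and urea variants assessed for ovarian cell inhibition

A few compounds are considered here, and "the series" means these few. Any claim that something is new, unique, unknown or untested is made for them only; others in the source may bear on it.

Compound 1 `COc1cc(-c2nn(-c3cccc(NC(=O)c4cccc(C(F)(F)F)c4)c3)cc2-c2ccncc2)ccc1Cl` gives 1200 nM in a functional assay on OVCAR-3 cells (Homo sapiens) for inhibition, read by sulforhodamine B assay, with a stated time of 48 h; on this read-out lower numbers stand for stronger inhibition and higher numbers for weaker inhibition.
Compound 2 `COc1cc(-c2nn(-c3cccc(NC(=O)Nc4ccc(Cl)c(Cl)c4)c3)cc2-c2ccncc2)ccc1Cl` gives 700 nM in this assay.
Compound 3 `COc1cc(-c2nn(-c3cccc(NC(=O)Nc4ccc(Cl)c(C(F)(F)F)c4)c3)cc2-c2ccncc2)ccc1Cl` gives 890 nM in this assay.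

Compound 3 sits second highest of the three numbers, with a 1.3-fold higher number from compound 2 to compound 3 (0.10 log units; within the scatter) and a 1.3-fold lower number from compound 1 to compound 3 (0.13 log units; within the scatter), so all three lie within scatter of one another. Compound 4 `COc1cc(-c2nn(-c3cccc(NC(=O)c4ccccc4)c3)cc2-c2ccncc2)ccc1Cl` differs from compound 3 by phenyl in place of (4-chloro-3-(trifluoromethyl)phenyl)amino on a carbonyl carbon. Within the data shown here, the only step bearing on this is the amide-to-urea comparison, a 1.3-fold lower number from compound 1 to compound 3 (0.13 log units; within the scatter), which was small; a 1.7-fold lower number from compound 1 to compound 2 (0.23 log units; within the scatter) was likewise small. Compound 4 goes further than compound 1 by also losing the trifluoromethyl, for which no direct comparison exists. The expected step is a 2.2-fold higher number from compound 3 to compound 4 (0.35 log units; beyond the scatter), a modest weakening with wide uncertainty. Compound 4 is therefore estimated at 2000 nM in this assay, within 800 nM to 5000 nM.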

Compound 4, half-maximal inhibitory concentration: 330 nM
Beside the measured number, compound 4's estimate is 6.1-fold (0.78 log units) above it; the measured number lies below the stated range.
By their numbers in this assay, from the lowest: compound 4; then compounds 2, 3 and 1 (each within the scatter of the next).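

Among these compounds, with phenyl on the carbonyl carbon, compound 4 separates from the other three compounds in this assay, which the earlier steps, all within the scatter, did not do: the two urea comparisons give a 2.7-fold lower number from compound 3 to compound 4 (0.43 log units; beyond the scatter) and a 2.1-fold lower number from compound 2 to compound 4 (0.33 log units; beyond the scatter). Within the amides alone, hydrogen in place of trifluoromethyl gives a 3.6-fold lower number from compound 1 to compound 4 (0.56 log units; beyond the scatter), so removing that single group from compound 1 is enough to produce a step beyond the scatter. No supporting measurement is available to explain these steps.

On these data alone, whether an unsubstituted phenylamino group on the same carbonyl carbon would match phenyl remains open, so the urea link and its ring substituents cannot yet be separated. Also open, as far as these compounds go, is how a fluoro or an amine on the phenyl ring would compare.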